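A few compounds are considered here, and "the series" means these few. Any claim that something is new, unique, unknown or untested is made for them only; others in the source may bear on it.

Among the measured compounds shown here, in a functional assay on KM12 cells (Homo sapiens) for cytotoxicity, read by sulforhodamine B assay, with a stated time of 48 h (on this read-out higher numbers stand for weaker inhibition of growth and lower numbers for stronger inhibition of growth), compound 1 (`COc1cc(C(=O)c2ccc(OC)c(O)c2OC)cc(OC)c1O`) gives 409 nM and stands lowest of the two numbers so far, with compound 2 (`COc1cc(C(=O)c2ccc3c(c2)oc(=O)n3S(C)(=O)=O)cc(OC)c1OC`) at 1150 nM and the gap beyond the scatter. Compound 3 (`COc1ccc(C(=O)c2cc(OC)c(OC)c(OC)c2)c(OC)c1O`) carries methyl in place of hydrogen on an oxygen on an aromatic ring, which reads as hydroxy to methoxy. For the measured compounds named here, no measured pair shows this change, so its size remains uncertain. In this assay a moderate step to lower numbers is expected (a 3.4-fold lower number from compound 1 to compound 3 (0.53 log units; beyond the scatter)), though a result within the scatter remains possible. Compound 3 is estimated at 120 nM (range 25 nM to 600 nM).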

Compound 3, concentration for 50% growth inhibition: < 10 nM
Compound 3: only a limit was reported (the forecaster's own chance of this, stated with the estimate: 3%); middle value at least 12-fold (1.07 log units) from the limit.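

In this assay the hydroxy to methoxy change now has a measured pair, showing an at least 40-fold lower number from compound 1 to compound 3 (1.61 log units; beyond the scatter) at this oxygen, so the hydrogen there is not needed for strong inhibition of growth. Compound 3 gives < 10 nM as a limit and not a number, so the full size of the step stays unfixed: the limit of < 10 nM in this assay, at which 1 of the 3 values shown sits.

Open, from the compounds shown here alone, is whether an ethyl group or a longer chain on this oxygen keeps the step. Also open, going by these compounds, is how an amine in place of the methoxy would read.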